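This account rests on a few compounds, and the source may have more. Where it says the series, first, only, none or still open, it means among the compounds named here.

Of the compounds shown here, three sharing one core have been tested in a functional assay on PC-3 cells (Homo sapiens) for inhibition, read by MTT assay, with a stated time of 48 h, tested at 10 uM (a lower number here means less inhibition of growth, a higher number more inhibition of growth at the concentration tested), and they differ only in the group on a saturated chain carbon bound to an aromatic carbon and an oxygen on a saturated carbon. Compound 1 `Cc1oc2c([C@H]3CCN(C)C[C@H]3O)c(O)cc(O)c2c(=O)c1C(O)c1ccc(F)c(Br)c1`, with 3-bromo-4-fluorophenyl there, gives 72%. Compound 2 `Cc1oc2c([C@H]3CCN(C)C[C@H]3O)c(O)cc(O)c2c(=O)c1C(O)c1c(Cl)cccc1Cl`, with 2,6-dichlorophenyl, gives 0%, and compound 3 `Cc1oc2c([C@H]3CCN(C)C[C@H]3O)c(O)cc(O)c2c(=O)c1C(O)c1c(F)cccc1Cl`, with 2-chloro-6-fluorophenyl, gives 0%. Compound 3 therefore stands level with compound 2 and far under compound 1.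

Compound 4 `Cc1oc2c([C@H]3CCN(C)C[C@H]3O)c(O)cc(O)c2c(=O)c1C(O)c1csc([N+](=O)[O-])c1` changes the same place, with 5-nitrothiophen-3-yl in place of 2-chloro-6-fluorophenyl on a saturated chain carbon bound to an aromatic carbon and an oxygen on a saturated carbon. The steps of a number 72 percentage points lower from compound 1 to compound 2 (beyond the scatter) and a number 72 percentage points lower from compound 1 to compound 3 (beyond the scatter) are both large and beyond the scatter, so a new group here can move the number a long way. The step of no change at the digits printed from compound 2 to compound 3 (within the scatter) is within the scatter, so trading chloro for fluoro on an aromatic carbon shows nothing. Within the data shown here, no tested compound carries a nitro group or a thiophene, so the size of the next step is poorly fixed. Compound 4 lacks chloro, like compound 1 and unlike compounds 2 and 3, and compound 3 at 0% leaves little room to fall. The expected change is upward, estimated as a number 30 percentage points higher from compound 3 to compound 4 (beyond the scatter). The estimate for compound 4 is 30%, with an expected range from 0% to 75%.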

Compound 4, percent growth inhibition at one concentration: 0%
The estimate for compound 4 lay 30 percentage points above the measured number; low and high end bracket the measured number.
By their numbers in this assay, from the lowest: compounds 2, 3 and 4 (each within the scatter of the next); then compound 1.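

In this assay, the new ring brings no change at the digits printed from compound 3 to compound 4 (within the scatter) and no change at the digits printed from compound 2 to compound 4 (within the scatter), yet compound 4 still falls short of the bromo and fluoro compound, with a number 72 percentage points lower from compound 1 to compound 4 (beyond the scatter). So the low reading at this position is not tied to chloro or to a six-membered ring: compound 4 has neither, and the 5-nitrothiophen-3-yl group with its hydrogen-bond acceptors reads level with the two chloro compounds, leaving compound 1 as the only one of the four with a reading clearly above the others. No supporting measurement is available to explain this result.

The compounds shown do not separate the parts of the 3-bromo-4-fluorophenyl group, so it remains open whether bromo, fluoro or the pair goes with the higher reading, which a phenyl carrying only bromo, only fluoro or neither could test. Going by these compounds, it is also open whether a thiophene without the nitro group, or a phenyl bearing an amine, would read differently from compound 4 at this position.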